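The source may hold more compounds than are shown below. What is called first, only, known or untested is meant among the compounds shown, and "the series" means these compounds.

Measured in a functional assay on A549 cells (Homo sapiens) for antiproliferative activity, read by MTT assay, with a stated time of 48 h; on this read-out lower numbers stand for stronger inhibition and higher numbers for weaker inhibition:
- Compound 1 `CN(C)CCn1c(N)c(-c2nc3ccccc3[nH]2)c2nc(C#N)c(C#N)nc21`: > 50000 nM, a limit of the assay, not a number.
- Compound 2 `N#Cc1nc2c(-c3nc4ccccc4[nH]3)c(N)n(CCN3CCCC3)c2nc1C#N`: > 50000 nM, also a limit of the assay.
- Compound 3 `CN(C)CCCn1c(N)c(-c2nc3ccccc3[nH]2)c2nc(C#N)c(C#N)nc21`: 10400 nM.

Compound 3 is the only one of the three with an actual number, and that number is the lowest shown. Compound 4 `CN1CCN(CCCn2c(N)c(-c3nc4ccccc4[nH]3)c3nc(C#N)c(C#N)nc32)CC1` keeps the propyl chain of compound 3 but ends in 4-methylpiperazin-1-yl in place of dimethylamino on a saturated chain carbon, three bonds along the chain from an aromatic nitrogen. Among the compounds with values here, the only measured swap of one amine for another, a step that the two limits leave unreadable from compound 1 to compound 2, gives no size to build on. The longer chain, which compound 4 retains, accounts for an at least 4.8-fold lower number from compound 1 to compound 3 (0.68 log units; beyond the scatter) and for an at least 4.8-fold lower number from compound 2 to compound 3 (0.68 log units; beyond the scatter). No step beyond the usual scatter is therefore expected in this assay, and the estimated change is a 1.3-fold higher number from compound 3 to compound 4 (0.13 log units; within the scatter). Compound 4 is expected at 14000 nM, with an estimated range of 4500 nM to 45000 nM.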

Compound 4, half-maximal inhibitory concentration: 5750 nM
Estimate against measurement, compound 4: 2.4-fold (0.39 log units) above, within the range that was stated.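

In this assay, the propyl chain carries 4-methylpiperazin-1-yl in place of dimethylamino with a 1.8-fold lower number from compound 3 to compound 4 (0.26 log units; within the scatter), so this six-membered ring amine is tolerated at this position. Both propyl compounds now stand apart from the shorter chains, with an at least 8.6-fold lower number from compound 2 to compound 4 (0.93 log units; beyond the scatter) and an at least 8.6-fold lower number from compound 1 to compound 4 (0.93 log units; beyond the scatter). These two steps rest on a limit of the assay for compound 1 and compound 2, not on numbers: the limit of > 50000 nM in this assay, at which 2 of the 4 values shown sit.

Still open, going by these compounds, is whether a morpholine or piperidine on the propyl chain would move the number beyond the scatter. On these data alone, a longer butyl chain remains equally open.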